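The source may hold more compounds than are shown below. What is called first, only, known or untested is meant among the compounds shown, and "the series" means these compounds.

Measured so far in a physicochemical assay for solubility, read by spectrophotometry, in phosphate buffer, with a stated time of 18 h, at pH 7.4; on this read-out lower numbers stand for lower solubility and higher numbers for higher solubility:
compound 1 `CCc1ccc(-c2nc3c(c(C)nn3-c3ccccc3)c(-c3ccccc3C(=O)O)c2C#N)cc1`: 33000 nM
compound 2 `CCc1ccc(-c2nc3c(c(C)nn3-c3ccccc3)c(-c3ccccc3C(=O)OC)c2C#N)cc1`: 17000 nM
compound 3 `Cc1nn(-c2ccccc2)c2nc(-c3ccc(C(C)C)cc3)c(C#N)c(-c3ccccc3O)c12`: 9800 nM

Compound 3 lies within the scatter of compound 2 and clearly under compound 1. Compound 4 `Cc1nn(-c2ccccc2)c2nc(-c3ccc(Cl)cc3)c(C#N)c(-c3ccccc3O)c12` differs from compound 3 as 4-isopropylphenyl to 4-chlorophenyl, chloro in place of isopropyl on an aromatic carbon. Going by the values given here, the only measured step, a 1.9-fold lower number from compound 1 to compound 2 (0.29 log units; within the scatter), is a different change at a different place, methyl in place of hydrogen on an oxygen, so it bears only loosely. Among the compounds with values here, with no measured precedent for this swap, no shift beyond the scatter is expected in this assay. The expected size is a 1.1-fold higher number from compound 3 to compound 4 (0.05 log units; within the scatter). Compound 4 is estimated at 11000 nM, with an expected range of 4000 nM to 30000 nM.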

Compound 4, solubility: 3800 nM
Compound 4: the middle estimate sits 2.9-fold (0.46 log units) above what was measured, and the stated range ends above it.
By their numbers in this assay, from the lowest: compound 4; then compounds 3, 2 and 1 (each within the scatter of the next, the first and the last beyond it).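

At the aromatic carbon para to a large group, chloro in place of isopropyl gives a 2.6-fold lower number from compound 3 to compound 4 (0.41 log units; beyond the scatter) in this assay and thus takes the read-out beyond the scatter. Going by these compounds alone, this is the first step to exceed the scatter, and it shows that the read-out responds to a change at this position, which the step on an oxygen could not show. Nothing at hand accounts for the shift and the explanation stays unresolved. Open, going by these compounds, is whether a methoxy group, an amine or a longer chain at this carbon would move the read-out in the same direction.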